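Dropping one chloro from the dichlorophenyl arm

The source may report more compounds than this note shows. Statements on the series, on what has been measured and on what is new or still open speak of the compounds shown alone.

Measured in a physicochemical assay for lipophilicity; a lower number here means a more polar compound, a higher number a more lipophilic compound:
- compound 1 `CC(C)(C)n1ncc(OCc2nnc(-c3ccc(Cl)cc3Cl)o2)c(Cl)c1=O`: 3.52
- compound 2 `CC(C)(C)n1ncc(OCc2nnc(-c3ccc(C(F)(F)F)cc3)o2)c(Cl)c1=O`: 3.66
- compound 3 `CC(C)(C)n1ncc(OCc2nnc(-c3cc(F)c(F)cc3F)o2)c(Cl)c1=O`: 2.96

Compound 1 sits close to compound 2, the two within the usual scatter of this assay, while compound 3 lies clearly lower: a number 0.56 log units lower from compound 1 to compound 3 (beyond the scatter).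

Compound 4 `CC(C)(C)n1ncc(OCc2nnc(-c3ccc(Cl)cc3)o2)c(Cl)c1=O` differs from compound 1 by hydrogen in place of chloro on an aromatic carbon. Going by the values given here, no measured step removes a single chloro; the only step on the same arm, a number 0.56 log units lower from compound 1 to compound 3 (beyond the scatter), swaps the whole 2,4-dichlorophenyl for 2,4,5-trifluorophenyl, so it bears on compound 4 only loosely. Removing one chlorine from compound 1 is nonetheless expected to give a modest drop in this assay, beyond the scatter.

The estimated step is a number 0.57 log units lower from compound 1 to compound 4 (beyond the scatter).

Compound 4 is therefore expected at 2.95, range 2.55 to 3.35.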

Compound 4, partition coefficient: 3.09
The estimate for compound 4 lay 0.14 log units below the measured number; low and high end bracket the measured number.
By their numbers in this assay, from the lowest: compounds 3 and 4 (each within the scatter of the next); then compounds 1 and 2 (each within the scatter of the next).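

The chloro ortho to a large group carries a step of its own in this assay (a number 0.43 log units lower from compound 1 to compound 4 (beyond the scatter)), the first single-atom change read on this arm. The 4-chlorophenyl and 2,4,5-trifluorophenyl arms are not separated (a number 0.13 log units higher from compound 3 to compound 4 (within the scatter)), whereas the chloro and trifluoromethyl arms are (a number 0.57 log units lower from compound 2 to compound 4 (beyond the scatter)). No measurement shown gives a reason for these steps.

Still open, from the compounds shown here alone, is how a methoxy group or a carboxylic acid in place of the chloro of the 4-chlorophenyl arm would read in this assay (this assay's scale alone would show it).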